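Chloro to tert-butyl at the meta position: compound 4

This account rests on a few compounds, and the source may have more. Where it says the series, first, only, none or still open, it means among the compounds named here.

Measured so far in an assay on microsomes for inhibition of acyl-CoA desaturase 1 (Mus musculus), with a stated time of 60 min; on this read-out higher numbers stand for weaker inhibition and lower numbers for stronger inhibition:
- compound 1 `Cc1ccc(C(=O)Nc2ncc(Cc3cccc(C(F)(F)F)c3)s2)cc1C`: 8220 nM
- compound 2 `COc1ccc(C(=O)Nc2ncc(Cc3cccc(F)c3)s2)cc1OCCO`: 2 nM
- compound 3 `COc1ccc(C(=O)Nc2ncc(Cc3cccc(Cl)c3)s2)cc1OCCO`: 1 nM

Among the measured compounds shown here, compound 3 and compound 2 sit within the scatter of each other, and the only single-point step among the measured compounds, a 2.0-fold lower number from compound 2 to compound 3 (0.30 log units; within the scatter), is itself within the scatter. Compound 1 lies far from both; it differs from compound 3 in more than one place, so its value can only be set beside the others, not read as a step.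

Compound 4 `COc1ccc(C(=O)Nc2ncc(Cc3cccc(C(C)(C)C)c3)s2)cc1OCCO` is not yet measured in this assay. The change from compound 3 is tert-butyl in place of chloro on an aromatic carbon. For the measured compounds named here, no measured step exchanges a halogen for a carbon group at this place, so the halogen-to-halogen step from compound 2 to compound 3 is the only one that bears on it, and it is small. Going by the values given here, compound 1, which carries trifluoromethyl at the same place but also a different amide, is the only compound with a non-halogen group there, and it gives a far higher number; how much of that comes from the group at this place is not separable.

For compound 4 a moderate rise is expected, a 5.0-fold higher number from compound 3 to compound 4 (0.70 log units; beyond the scatter). The estimate for compound 4 is 5 nM, with a range from 1 nM to 40 nM.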

Compound 4, half-maximal inhibitory concentration: 1310 nM
Compound 4: the middle estimate sits 260-fold (2.42 log units) below what was measured; measured number outside the range, above it.
By their numbers in this assay, from the lowest: compounds 3 and 2 (each within the scatter of the next); then compound 4; then compound 1.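

In this assay, this place on the shared core proved far from indifferent to the group it carries. Fluoro and chloro remain within the scatter of each other, but tert-butyl, with 4 heavy atoms where chloro has 1, gives a 1300-fold higher number from compound 3 to compound 4 (3.12 log units; beyond the scatter) and a 660-fold higher number from compound 2 to compound 4 (2.82 log units; beyond the scatter), so the two halogens do not speak for every group here. Among the compounds shown here, this is also the first evidence that one exchange at this place, with the rest of the molecule held fixed, can carry a large step, and nothing at hand bears on why it does.

Open, going by these compounds, is how the number behaves for carbon groups such as methyl, ethyl or isopropyl, and therefore whether the rise is gradual or abrupt on the way from chloro to tert-butyl. Also open, on these data alone, are an amine or a carboxylic acid at this place, and where trifluoromethyl would fall on the core of compound 4, as compound 1 carries that group with a different amide.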